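The source may report more compounds than this note shows. Statements on the series, on what has been measured and on what is new or still open speak of the compounds shown alone.

Working notes on the resorcinol-isoxazole amide series, measured in a functional assay on A2780 cells (Homo sapiens) for inhibition; a lower number here means a stronger inhibitor, a higher number a weaker inhibitor. Compound 1 `CCNC(=O)c1noc(-c2cc(C(C)C)c(O)cc2O)c1-c1cc(CN)no1` carries no result in this assay: for compound 1 the entry reads "not determined" (no result reported). Compound 3 `CCCNCc1cc(-c2c(C(=O)NCC)noc2-c2cc(C(C)C)c(O)cc2O)on1` likewise carries no result: for compound 3 the entry reads "not determined" (no result reported). Within the data shown here, compound 2 `CCNCc1cc(-c2c(C(=O)NCC)noc2-c2cc(C(C)C)c(O)cc2O)on1` is the only member with a number: in this assay compound 2 gives 45 nM, so it stands alone as the reference point, with no second value to rank it against.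

Compound 4 `CCNC(=O)c1noc(-c2cc(C(C)C)c(O)cc2O)c1-c1cc(C(=O)O)no1` differs from compound 2 in one place: carboxy in place of (ethylamino)methyl on an aromatic carbon. No comparison of two measured compounds exists in the series to anchor the size of such a change, so the expected step rests on the structural change alone. The step from compound 2 to compound 4 is expected to be a 13-fold higher number from compound 2 to compound 4 (1.12 log units; beyond the scatter), toward a higher number, beyond the usual scatter. For compound 4 the estimate in this assay is 600 nM, in the range 120 nM to 3000 nM.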

Compound 4, half-maximal inhibitory concentration: 20000 nM
The estimate for compound 4 lay 33-fold (1.52 log units) below the measured number; measured number outside the range, above it.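

Among these compounds, the step of a 440-fold higher number from compound 2 to compound 4 (2.65 log units; beyond the scatter) in this assay is the first measured change, and it falls on the aromatic carbon next to the ring nitrogen. With the rest of the structure held constant, carboxy in place of (ethylamino)methyl at this one position moves the number well beyond the scatter. Nothing available bears on the cause of this step. Open, as far as these compounds go, is whether a methyl ester or a hydroxymethyl group here would read closer to compound 2 or to compound 4. Also open, from the compounds shown here alone, is how a longer amine chain would compare with (ethylamino)methyl.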